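A few compounds are considered here, and "the series" means these few. Any claim that something is new, unique, unknown or untested is made for them only; others in the source may bear on it.

For the measured compounds named here, compound 3 `O=C(Nc1cc(-c2ccccc2)nn1-c1ccccc1)c1ccccn1` gives 585 nM in an assay on isolated protein with metabotropic glutamate receptor 5 (Rattus norvegicus) as the target (on this read-out lower numbers stand for an effect already at smaller amounts and higher numbers for an effect only at larger amounts of compound), and stands highest of the three numbers so far. Compound 1 `O=C(Nc1cc(-c2ccccc2)nn1-c1ccccc1)c1ccc(F)cc1` gives 50 nM and compound 2 `Cc1ccc(C(=O)Nc2cc(-c3ccccc3)nn2-c2ccccc2)cc1` gives 40 nM; between them, a 1.3-fold lower number from compound 1 to compound 2 (0.10 log units; within the scatter). Both large steps that set compound 3 apart, a 12-fold higher number from compound 1 to compound 3 (1.07 log units; beyond the scatter) and a 15-fold higher number from compound 2 to compound 3 (1.17 log units; beyond the scatter), place pyridin-2-yl on the carbonyl carbon in exchange for a substituted phenyl. Compound 4 `O=C(Nc1cc(-c2ccccc2)nn1-c1ccccc1)c1ccccc1F` reverses that exchange: 2-fluorophenyl in place of pyridin-2-yl on a carbonyl carbon. Going by the values given here, the ring entering is 2-fluorophenyl rather than the 4-fluorophenyl of compound 1, so no measured step matches it exactly. Still, a large fall in this assay is expected because a 12-fold higher number from compound 1 to compound 3 (1.07 log units; beyond the scatter) and a 15-fold higher number from compound 2 to compound 3 (1.17 log units; beyond the scatter) ran the other way. The expected step is a 5.9-fold lower number from compound 3 to compound 4 (0.77 log units; beyond the scatter). Compound 4 is therefore estimated at 100 nM, with a range from 30 nM to 400 nM.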

Compound 4, half-maximal effective concentration: 100 nM
Beside the measured number, compound 4's estimate shows no gap at the digits printed; low and high end bracket the measured number.
By their numbers in this assay, from the lowest: compounds 2, 1 and 4 (each within the scatter of the next, the first and the last beyond it); then compound 3.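

On the carbonyl carbon in this assay, a third carbon-only ring also undoes much of the rise seen with pyridin-2-yl (a 5.9-fold lower number from compound 3 to compound 4 (0.77 log units; beyond the scatter)), so this reversal no longer rests on the rings of compound 1 and compound 2 alone. The exchange of 4-fluorophenyl for 2-fluorophenyl stays within the scatter (a 2.0-fold higher number from compound 1 to compound 4 (0.30 log units; within the scatter)), whereas the exchange of 4-methylphenyl for 2-fluorophenyl lies beyond it (a 2.5-fold higher number from compound 2 to compound 4 (0.40 log units; beyond the scatter)). No evidence at hand accounts for these steps. Open, as far as these compounds go, is how a phenyl ring carrying an amine or a carboxylic acid would read on this carbonyl carbon. Also open, from the compounds shown here alone, is whether 2-methylphenyl would track 2-fluorophenyl here.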